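The compounds below may be only part of what the source reports. "The series", "measured", "known", "first", "only" and "open" are said of these compounds alone.

Measured compounds in a functional assay on the whole organism for inhibition, with Rattus norvegicus as the target; on this read-out lower numbers stand for an effect already at smaller amounts and higher numbers for an effect only at larger amounts of compound:
compound 1, `CC(C)c1ccc(OC(Cc2ccccc2)C(=O)O)cc1`: 50 mg/kg
compound 2, `CC(C)c1ccc(OC(C)(Cc2ccccc2)C(=O)O)cc1`: a limit, > 10 mg/kg
compound 3, `CCc1cccc(CC(C)(Oc2ccc(C(C)C)cc2)C(=O)O)c1`: 0.5 mg/kg

Compound 2 is compound 1 with methyl in place of hydrogen on a saturated chain carbon bound to a carbonyl carbon, an oxygen on an aromatic ring and a saturated chain carbon. The step that the limit leaves unreadable from compound 1 to compound 2 cannot be sized; compound 2 sits at the limit of > 10 mg/kg in this assay, at which 1 of the 3 values shown sits. Compound 3 adds an ethyl in place of hydrogen on an aromatic carbon, and this gives an at least 20-fold lower number from compound 2 to compound 3 (1.30 log units; beyond the scatter). Compound 3 thus shows the lower of the two numbers, compound 1 the higher; how the core of compound 3 differs from the core of compound 1 is not broken down here.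

Compound 4, `CCCc1cccc(CC(C)(Oc2ccc(C(C)C)cc2)C(=O)O)c1`, is compound 3 with methyl in place of hydrogen on a saturated chain carbon, two bonds along the chain from an aromatic carbon. This is the same kind of change as from compound 1 to compound 2, though not the same: there the methyl enters on a saturated chain carbon bound to a carbonyl carbon, an oxygen on an aromatic ring and a saturated chain carbon, here on a saturated chain carbon two bonds along the chain from an aromatic carbon, where the change reads ethyl to propyl. The earlier step offers no readable size, so the expectation for compound 4 rests on compound 3 and its 0.5 mg/kg alone, with an expected step of no change at the digits printed from compound 3 to compound 4 (within the scatter) in this assay. Compound 4 is estimated at 0.5 mg/kg, between 0.15 mg/kg and 1.6 mg/kg.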

Compound 4, dose for half-maximal effect: 1 mg/kg
For compound 4 the middle estimate is 2.0-fold (0.30 log units) below the measured one; low and high end bracket the measured number.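

In this assay, methyl in place of hydrogen on a saturated chain carbon, two bonds along the chain from an aromatic carbon, turns ethyl into propyl and gives a 2.0-fold higher number from compound 3 to compound 4 (0.30 log units; within the scatter), so on this core the change stays within the scatter. Seen from the other side, the propyl step gives an at least 10-fold lower number from compound 2 to compound 4 (1.00 log units; beyond the scatter), which lies beyond the scatter, as does the ethyl step, an at least 20-fold lower number from compound 2 to compound 3 (1.30 log units; beyond the scatter). Whether the methyl change carries over from one core to another is not shown, since the step from compound 1 to compound 2 cannot be read, compound 2 being held only by a limit: the limit of > 10 mg/kg in this assay, at which 1 of the 4 values shown sits.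

The compounds shown leave open how a longer chain such as butyl, or a methoxy group or an amine, would read in the place of the ethyl on this core. They also leave open whether an amide could stand in for the carboxylic acid.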